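Moving one chlorine on the dichlorophenyl group

The compounds below may be only part of what the source reports. "The series", "measured", "known", "first", "only" and "open" are said of these compounds alone.

In a functional assay on MDA-MB-231 cells (Homo sapiens) for antiproliferative activity, read by MTT assay, with a stated time of 48 h (a higher number here means a weaker inhibitor, a lower number a stronger inhibitor), compound 1 `C#Cc1cccc(Nc2ncnc3cc(NC(=O)/C=C/c4ccccc4)sc23)c1` gives 2340 nM and compound 2 `O=C(/C=C/c1ccccc1)Nc1cc2ncnc(Nc3ccc(F)c(Cl)c3)c2s1` gives 2100 nM while compound 3 `O=C(/C=C/c1ccccc1)Nc1cc2ncnc(Nc3cc(Cl)cc(Cl)c3)c2s1` gives 1000 nM as the lowest number of the three. Compound 4 `O=C(/C=C/c1ccccc1)Nc1cc2ncnc(Nc3ccc(Cl)c(Cl)c3)c2s1` has not yet been measured. It differs from compound 3 by a single change: 3,4-dichlorophenyl in place of 3,5-dichlorophenyl on a nitrogen on an aromatic ring with 3,4-dichlorophenyl in place of 3,5-dichlorophenyl on a nitrogen on an aromatic ring. For the measured compounds named here, no measured pair shows this exact change, but three steps at the same place bear on it. Modest steps appear in a 2.1-fold lower number from compound 2 to compound 3 (0.32 log units; beyond the scatter) and in a 2.3-fold lower number from compound 1 to compound 3 (0.37 log units; beyond the scatter) while a 1.1-fold lower number from compound 1 to compound 2 (0.05 log units; within the scatter) stays within the scatter. Changes at this place have so far been small, so only a small upward move is expected. The expected size is a 1.5-fold higher number from compound 3 to compound 4 (0.18 log units; within the scatter) in this assay which would not clearly separate the two compounds. Compound 4 is estimated at 1500 nM with 750 nM and 3000 nM as the ends of the expected range.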

Compound 4, half-maximal inhibitory concentration: 2410 nM
Compound 4: middle estimate off by 1.6-fold (0.21 log units), on the low side; measured number inside the range.
By their numbers in this assay, from the lowest: compound 3; then compounds 2, 1 and 4 (each within the scatter of the next).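

In this assay, moving one chlorine is enough for a step beyond the scatter, even though the two groups have the same atoms (a 2.4-fold higher number from compound 3 to compound 4 (0.38 log units; beyond the scatter)), so this position responds to how the chlorines are arranged and not only to which atoms are present. With the 3,4-arrangement, chloro in place of fluoro leaves the number within the scatter (a 1.1-fold higher number from compound 2 to compound 4 (0.06 log units; within the scatter)), and so does the exchange of 3-ethynylphenyl for 3,4-dichlorophenyl (a 1.0-fold higher number from compound 1 to compound 4 (0.01 log units; within the scatter)). Compounds 1, 2 and 4 therefore cannot be told apart, and only compound 3, with its 3,5-dichlorophenyl group, stands clear of all the others.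

Nothing given here accounts for the difference between the two dichlorophenyl groups. On these data alone, it also remains open whether bromine atoms or methoxy groups in place of the two chlorines of compound 3 would keep its low number.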